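Swapping the Piperidine for a Cyclopentyl Sulfide

The compounds below may be only part of what the source reports. "The series", "measured", "known", "first", "only" and "open" are said of these compounds alone.

Compound 1 `CCC1CCN(c2cc(C(F)(F)F)ccc2CNC(=O)C(C)c2ccc(NS(C)(=O)=O)c(F)c2)CC1` is the starting point. Among the measured compounds shown here, in an assay on CHO cells for antagonist activity at transient receptor potential cation channel subfamily V member 1 (Homo sapiens), read by FLIPR (on this read-out higher numbers stand for weaker inhibition and lower numbers for stronger inhibition), compound 1 gives 0.7 nM, the lowest of the two numbers known so far. Its closest neighbour is compound 2 `CC(C(=O)NCc1ccc(C(F)(F)F)cc1N1CCC(C)(C)CC1)c1ccc(NS(C)(=O)=O)c(F)c1`, which in this assay gives 1.3 nM; the step of a 1.9-fold higher number from compound 1 to compound 2 (0.27 log units; within the scatter) shows that exchanging one piperidine ring for another at this position leaves the number essentially unchanged.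

Compound 3 `CC(C(=O)NCc1ccc(C(F)(F)F)cc1SC1CCCC1)c1ccc(NS(C)(=O)=O)c(F)c1` has not yet been measured. It differs from compound 1 by cyclopentylsulfanyl in place of 4-ethylpiperidin-1-yl on an aromatic carbon, a change at the same aromatic carbon that was varied between compound 1 and compound 2, but a deeper one: the nitrogen-linked six-membered ring gives way to a sulfur-linked five-membered ring. For the measured compounds named here, the one measured step at this position stayed within the scatter, so the only directly relevant evidence argues for tolerance, yet it covers a far smaller change than the one made here. The expectation for compound 3 is therefore a modest weakening, a 2.9-fold higher number from compound 1 to compound 3 (0.46 log units; beyond the scatter), with wide uncertainty. Compound 3 is estimated at 2 nM, within the range 0.5 nM to 10 nM.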

Compound 3, inhibition constant: 0.3 nM
Estimate against measurement, compound 3: 6.7-fold (0.82 log units) above; the whole stated range lies above it.
By their numbers in this assay, from the lowest: compound 3; then compounds 1 and 2 (each within the scatter of the next).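

The position on the aromatic carbon turns out to tolerate more than a swap between piperidines: in this assay, the piperidine nitrogen can give way to a sulfur link without any loss. Cyclopentylsulfanyl gives a 2.3-fold lower number from compound 1 to compound 3 (0.37 log units; beyond the scatter) and, against the other piperidine, a 4.3-fold lower number from compound 2 to compound 3 (0.64 log units; beyond the scatter), so both steps lie beyond the scatter, unlike the earlier exchange of one piperidine for another, and both point towards stronger inhibition even though the group entering is the smaller by the count of heavy atoms. Nothing available here explains why this group gives the lower number.

The sulfur link and the five-membered ring of carbon only entered together, so these compounds cannot say which of the two accounts for the step, and a cyclopentyloxy group, with oxygen as the link, or a cyclohexylsulfanyl group, with a six-membered ring on the same sulfur link, would separate them. Going by these compounds, it also remains open whether the ring is needed at all, a question that an open chain such as butylsulfanyl, or a sulfur link carrying a terminal amine, would address.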